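A few compounds are considered here, and "the series" means these few. Any claim that something is new, unique, unknown or untested is made for them only; others in the source may bear on it.

Compound 1 `O=C(Nc1ccc(C(F)(F)F)cc1)c1cccc(Nc2ncc(F)c(Nc3ccc(F)cc3)n2)c1`: > 10000 nM, a limit of the assay.
Compound 2 `O=C(Nc1cccc(Nc2ncc(F)c(Nc3ccc(F)cc3)n2)c1)c1cccc([N+](=O)[O-])c1`: 7250 nM.

Among the measured compounds shown here, in a functional assay on A549 cells (Homo sapiens) for antiproliferative activity, read by sulforhodamine B assay, with a stated time of 3 days (a lower number here means a stronger inhibitor of growth, a higher number a weaker inhibitor of growth), compound 2 holds the only actual number so far, 7250 nM. Compound 3 `CN(C)c1ccc(C(=O)Nc2cccc(Nc3ncc(F)c(Nc4ccc(F)cc4)n3)c2)cc1` is still unmeasured and carries 4-(dimethylamino)phenyl in place of 3-nitrophenyl on a carbonyl carbon. For the measured compounds named here, no measured step covers this change, so no shift beyond the usual scatter is expected in this assay. The expected step is a 1.1-fold lower number from compound 2 to compound 3 (0.05 log units; within the scatter). For compound 3 the estimate is 6500 nM, with an expected range of 2500 nM to 10000 nM.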

Compound 3, concentration for 50% growth inhibition: > 10000 nM
Compound 3: a limit, no number (the forecaster's own chance of this, stated with the estimate: 35%); middle value at least 1.5-fold (0.18 log units) away from the limit.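

In this assay, among the compounds shown here, 4-(dimethylamino)phenyl in place of 3-nitrophenyl on a carbonyl carbon gives the first readable step at this position: an at least 1.3-fold higher number from compound 2 to compound 3 (0.13 log units; that floor lies within the scatter). Compound 3 gives > 10000 nM, which is a limit and not a number. This change therefore does not lower the number, and the true size of the step stays unread: the limit of > 10000 nM in this assay, at which 2 of the 3 values shown sit.

Still open, from the compounds shown here alone, is whether any group on this carbonyl carbon can bring the number well down from that of compound 2, which gives 7250 nM. A phenyl carrying a carboxylic acid or a primary amine would test this.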